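Moving the Methoxy Group Around the Benzyl Ring

The source may report more compounds than this note shows. Statements on the series, on what has been measured and on what is new or still open speak of the compounds shown alone.

Compound 2 `COc1ccc(CNCCCNS(=O)(=O)c2cc(C(F)(F)F)cc(C(F)(F)F)c2)cc1` is one of only two measured sulfonamides here; in a functional assay on MCF7 cells (Homo sapiens) for inhibition, read by MTT assay, with a stated time of 72 h (on this read-out lower numbers stand for stronger inhibition of growth and higher numbers for weaker inhibition of growth), compound 2 gives 2500 nM. Among the compounds with values here, its single neighbour, compound 1 `COc1ccc(CNCCCNS(=O)(=O)c2cc(C(F)(F)F)cc(C(F)(F)F)c2)cc1OC`, gives 1900 nM in this assay, so the two values sit within the scatter of one another, and the step of a 1.3-fold higher number from compound 1 to compound 2 (0.12 log units; within the scatter) arises from hydrogen in place of methoxy on an aromatic carbon. Compound 3 `COc1ccccc1CNCCCNS(=O)(=O)c1cc(C(F)(F)F)cc(C(F)(F)F)c1` holds the same atoms as compound 2, differing by 2-methoxyphenyl in place of 4-methoxyphenyl on a saturated chain carbon bound to an amine nitrogen. Within the data shown here, no measured pair covers this change directly. Among the measured compounds shown here, the only step available, a 1.3-fold higher number from compound 1 to compound 2 (0.12 log units; within the scatter), shows that removing a methoxy group from that ring left the read-out of this assay essentially unchanged, so simply relocating the methoxy group is expected to give no step beyond the scatter. For compound 3 in this assay the estimated value is 2500 nM, with a range from 1200 nM to 5200 nM. The expected step is therefore no change at the digits printed from compound 2 to compound 3 (within the scatter).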

Compound 3, concentration for 50% growth inhibition: 2600 nM
For compound 3 the middle estimate is 1.0-fold (0.02 log units) below the measured one, within the range that was stated.
By their numbers in this assay, from the lowest: compounds 1, 2 and 3 (each within the scatter of the next).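

In this assay, within the data shown here, 2-methoxyphenyl in place of 4-methoxyphenyl on a saturated chain carbon bound to an amine nitrogen gives a 1.0-fold higher number from compound 2 to compound 3 (0.02 log units; within the scatter), so where the single methoxy group sits on the ring does not separate these two compounds. The earlier compounds shown here had varied only the number of methoxy groups, whereas a 1.4-fold higher number from compound 1 to compound 3 (0.14 log units; within the scatter) shows that a change in both number and location, 2-methoxyphenyl in place of 3,4-dimethoxyphenyl, also stays inside the scatter. No supporting evidence bears on why these values lie together.

As far as these compounds go, what remains open is whether a hydroxyl group, a chlorine or a dimethylamino group on that ring would stand apart from the methoxy compounds in this assay. From the compounds shown here alone, it is equally open whether an amide in place of the amine would keep the values together.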